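The source may hold more compounds than are shown below. What is called first, only, known or untested is meant among the compounds shown, and "the series" means these compounds.

In a functional assay with Alpha-1A adrenergic receptor (Homo sapiens) as the target, read by calcium flux (on this read-out higher numbers stand for larger maximal responses and lower numbers for smaller maximal responses), compound 1 `Cn1cccc1-c1ccccc1NCC1=NCCN1` gives 103% and compound 3 `CCn1cccc1-c1ccccc1NCC1=NCCN1` gives 93%. The two differ by hydrogen in place of methyl on a saturated chain carbon bound to an aromatic nitrogen, and this step reads a number 10 percentage points higher from compound 3 to compound 1 (within the scatter). Compound 2 `CC(C)n1nccc1-c1ccccc1NCC1=NCCN1` sits on a different core; how its core differs from that of compound 3 is not broken down here. In this assay compound 2 gives 0%. Compound 4 `CCn1nccc1-c1ccccc1NCC1=NCCN1` is unmeasured and differs from compound 2 by hydrogen in place of methyl on a saturated chain carbon bound to an aromatic nitrogen and a saturated chain carbon. This is the same kind of change as that from compound 3 to compound 1, though here the place also carries a saturated chain carbon. Because the earlier step of a number 10 percentage points higher from compound 3 to compound 1 (within the scatter) stayed within the scatter, the step of a number 20 percentage points higher from compound 2 to compound 4 (beyond the scatter) is expected to be modest too, yet the low value of compound 2 0% leaves open whether the core or the isopropyl accounts for it. For compound 4 the estimate is 20%, between 0% and 65%.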

Compound 4, largest response reached (reported as maximal response), in percent of the reference or control that the assay uses: 81%
Estimate against measurement, compound 4: 61 percentage points below, and the stated range ends below it.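

Removing one methyl from the chain on the aromatic nitrogen does not carry over evenly from one core to the other in this assay: the same change on two cores in this assay, a number 10 percentage points higher (within the scatter) from compound 3 to compound 1 and a number 81 percentage points higher (beyond the scatter) from compound 2 to compound 4, 71 percentage points apart, beyond the scatter of two such steps. Going from isopropyl to ethyl gives a number 81 percentage points higher from compound 2 to compound 4 (beyond the scatter), so a small step on one core does not predict the size of the step on the other. These two pairs do not show whether the core or the starting chain sets the size of the step, as the core and the chain both differ between them.

An isopropyl group on the core of compound 1 and a methyl group on the core of compound 4 would help separate these two influences. As far as these compounds go, how a longer chain such as propyl, or a cyclopropyl ring, would read on either core also remains open.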